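This account rests on a few compounds, and the source may have more. Where it says the series, first, only, none or still open, it means among the compounds named here.

In a functional assay on HCT-116 cells (Homo sapiens) for cytotoxicity, read by CellTiter-Glo, with a stated time of 5 days (on this read-out lower numbers stand for stronger inhibition and higher numbers for weaker inhibition), compound 1 `Cc1cc(Nc2nn(Cc3ccc(S(C)(=O)=O)cc3)c(=O)c3ccccc23)n[nH]1` gives 1700 nM and compound 2 `Cc1cc(Nc2nn(Cc3cc(F)ccc3F)c(=O)c3ccccc23)n[nH]1` gives 570 nM. Compound 2 therefore holds the lower of the two numbers, and the gap lies beyond the usual scatter of repeat measurements. Compound 3 `Cc1ccc(-n2nc(Nc3cc[nH]n3)c3ccccc3c2=O)cc1` offers no comparison, since its entry reads "not determined" (no result reported).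

Compound 4 `Cc1cc(Nc2nn(Cc3csc(C)n3)c(=O)c3ccccc23)n[nH]1` differs from compound 2 in one place: 2-methyl-1,3-thiazol-4-yl in place of 2,5-difluorophenyl on a saturated chain carbon bound to an aromatic nitrogen. In words, 2-methyl-1,3-thiazol-4-yl stands in place of 2,5-difluorophenyl on a saturated chain carbon bound to an aromatic nitrogen.

Among the compounds with values here, no measured pair shows this exact swap, so any expectation rests on thin evidence. Compound 1 at 1700 nM and compound 2 at 570 nM carry different groups at this place, and their numbers differ clearly. Since compound 2 has the lower number, a modest move upward, meaning weaker inhibition, is expected, no larger than about the gap between those two compounds. The expected change is a 1.8-fold higher number from compound 2 to compound 4 (0.24 log units; within the scatter). The estimate for compound 4 is 1000 nM, with an expected range of 300 nM to 3000 nM.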

Compound 4, half-maximal inhibitory concentration: 4180 nM
The estimate for compound 4 lay 4.2-fold (0.62 log units) below the measured number; measured number outside the range, above it.
By their numbers in this assay, from the lowest: compound 2; then compound 1; then compound 4.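

In this assay, the group on a saturated chain carbon bound to an aromatic nitrogen can shift the result well beyond the usual scatter: the swap gives a 7.3-fold higher number from compound 2 to compound 4 (0.87 log units; beyond the scatter) in this single one-place comparison. It shows that 2-methyl-1,3-thiazol-4-yl, a five-membered aromatic ring with 2 hetero atoms, does not match 2,5-difluorophenyl here and goes with weaker inhibition. No supporting measurement speaks to the reason for this loss.

The compounds shown leave open whether the loss goes with the thiazole ring itself or with its methyl group. They also leave open how a plain phenyl ring, a pyridine ring or a morpholine-bearing chain would read at this place in this assay.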